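The source may hold more compounds than are shown below. What is called first, only, known or untested is meant among the compounds shown, and "the series" means these compounds.

Measured compounds:
Compound 1 `COc1ccc(/C(Cl)=C/C=C(\C#N)C(=O)c2c(C)[nH]c3ccccc23)cc1` gives 74% in a functional assay for inhibition, read by Griess assay, with a stated time of 150 min, tested at 1 mM; a lower number here means less inhibition, a higher number more inhibition at the concentration tested (going by the name of the read-out).
Compound 2 `COc1cc(/C(Cl)=C/C=C(\C#N)C(=O)c2c[nH]c3ccc(Br)cc23)cc(OC)c1OC` gives 36.7% in this assay.
Compound 3 `Cc1[nH]c2ccccc2c1C(=O)/C(C#N)=C/C=C(\Cl)c1ccc(Br)cc1` gives 78.3% in this assay.

Compound 2 stands lowest of the three, and both compound 1 and compound 3 lie beyond the scatter above it. Compound 3 and compound 1 differ in one place, (methoxy in place of bromo on an aromatic carbon), and the step of a number 4.3 percentage points lower from compound 3 to compound 1 (within the scatter) lies within the scatter. The difference between the core of compound 2 and the core of compound 3 is not broken down here.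

Compound 4 `COc1ccc2[nH]cc(C(=O)/C(C#N)=C/C=C(\Cl)c3cc(OC)c(OC)c(OC)c3)c2c1` is not yet measured in this assay. It differs from compound 2 by methoxy in place of bromo on an aromatic carbon. This is the same kind of change as from compound 3 to compound 1, but the place differs: in compound 4 the carbon belongs to a six-membered aromatic ring of carbon only that is part of a fused or bridged system of two rings, meta to a fused ring and para to a fused ring, whereas in compound 1 it sits para to a large group. Because a number 4.3 percentage points lower from compound 3 to compound 1 (within the scatter) lay within the scatter, the step from compound 2 to compound 4 is expected to be small, a number 0.3 percentage points higher from compound 2 to compound 4 (within the scatter). Compound 4 is therefore estimated to give 37% in this assay, expected between 22% and 52%.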

Compound 4, a percentage reported as inhibition, at one concentration (the size of the read-out at that concentration, not a potency): 68.3%
Compound 4: the middle estimate sits 31.3 percentage points below what was measured; the whole stated range lies below it.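

In this assay, methoxy in place of bromo on an aromatic carbon gave a large step on the core of compound 2, a number 31.6 percentage points higher from compound 2 to compound 4 (beyond the scatter), so the change did not carry over unchanged between the two pairs: the same change on two cores in this assay, a number 4.3 percentage points lower (within the scatter) from compound 3 to compound 1 and a number 31.6 percentage points higher (beyond the scatter) from compound 2 to compound 4, 35.9 percentage points apart, beyond the scatter of two such steps. This shows that, in this series, the size of the step read on one core was no safe guide to its size on the other. It does not show what sets the two steps apart: the pairs differ at once in the core, in the place of the change and in the other groups they carry, and two pairs give no rule for any further core.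

The compounds shown leave open how the place held by bromo in compound 2 would respond to groups other than methoxy, such as an amine, a carboxylic acid or a longer chain. They also leave open whether the same change on other cores would follow the smaller step or the larger one.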